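The source may hold more compounds than are shown below. What is called first, only, known or untested is meant among the compounds shown, and "the series" means these compounds.

Measured compounds:
- compound 1, `NS(=O)(=O)c1ccc(N2N=C(c3ccc(OCc4ccccc4)cc3)CC2c2ccc(F)cc2)cc1`, with 60000 nM in an ADME assay on BHK-21 cells (Mesocricetus auratus) for cytotoxicity, read by MTT assay, with a stated time of 72 h; on this read-out higher numbers stand for lower toxicity in this test and lower numbers for higher toxicity in this test
- compound 2, `Cc1cccc(C2CC(c3ccc(Oc4ccccc4)cc3)=NN2c2ccc(S(N)(=O)=O)cc2)c1`, with 8000 nM in this assay
- compound 3, `Cc1ccc(C2CC(c3ccc(OCc4ccccc4)cc3)=NN2c2ccc(S(N)(=O)=O)cc2)cc1`, with 32000 nM in this assay

Compounds 3 and 1 share a core and differ in one place only: fluoro in place of methyl on an aromatic carbon. That change made a 1.9-fold higher number from compound 3 to compound 1 (0.27 log units; within the scatter), so on its own it did not move the read-out in a way that can be told apart from repeat measurement.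

Compound 2 has the lowest of the three numbers in this assay, and its gaps to compound 3 and to compound 1 both lie beyond the scatter. How the core of compound 2 differs from the core of compound 3 is not broken down here.

Compound 4, `NS(=O)(=O)c1ccc(N2N=C(c3ccc(Oc4ccccc4)cc3)CC2c2cccc(F)c2)cc1`, has not yet been measured. It is related to compound 2 by fluoro in place of methyl on an aromatic carbon. Among the measured compounds shown here, this is the same kind of change as the one between compound 3 and compound 1, but not the same: there the fluoro sits para to a large group, here it sits meta to a large group.

Because a 1.9-fold higher number from compound 3 to compound 1 (0.27 log units; within the scatter) stayed within the scatter, the step from compound 2 to compound 4 is expected to be of a similar modest size, a 1.4-fold higher number from compound 2 to compound 4 (0.14 log units; within the scatter). For the measured compounds named here, for compound 4 in this assay the estimate is 11000 nM, with a plausible range from 4500 nM to 27000 nM, resting on the single precedent and on the value of compound 2.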

Compound 4, half-maximal cytotoxic concentration: 10000 nM
Compound 4: the middle estimate sits 1.1-fold (0.04 log units) above what was measured; the range from low to high includes it.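

In this assay, fluoro in place of methyl, here 3-methylphenyl to 3-fluorophenyl, gave a 1.3-fold higher number from compound 2 to compound 4 (0.10 log units; within the scatter), so compound 2 and compound 4 cannot be told apart from what repeat measurement alone would give. The earlier pair behaved the same way, and the two steps agree as closely as two such steps can be expected to: the same change on two cores in this assay, a 1.9-fold higher number (0.27 log units; within the scatter) from compound 3 to compound 1 and a 1.3-fold higher number (0.10 log units; within the scatter) from compound 2 to compound 4, 1.5-fold (0.18 log units) apart, within the scatter of two such steps On these two cores, then, the swap of methyl for fluoro carried across with no readable effect on the number, but two pairs are too few to make a rule for the whole series, the fluoro does not sit in the same place in both, and steps this small cannot reveal whether a real but slight effect is hiding in the scatter.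

The compounds shown leave open whether a different group in this place, such as an amine, a carboxylic acid or a longer chain, would give a step that rises clearly above the scatter. They also leave open whether fluoro and methyl would still match at other places on the same ring.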